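Swapping chloro for fluoro on the shared core

The source may hold more compounds than are shown below. What is called first, only, known or untested is meant among the compounds shown, and "the series" means these compounds.

For the measured compounds named here, the three compounds measured so far share one core and differ only in the group attached to the carbonyl carbon. Compound 1, `COc1cc(C2CC(=NOC(=O)c3ccc(Cl)cc3)CC(c3ccc(O)c(OC)c3)N2C)ccc1O`, gives 121000 nM in a functional assay on microsomes from liver (Rattus norvegicus, strain Wistar) for inhibition, read by spectrophotometry, with a stated time of 60 min (a lower number here means a stronger inhibitor, a higher number a weaker inhibitor), the highest number of the three, so it is the weakest inhibitor shown. Compound 3, `COc1cc(C2CC(=NOC(=O)c3ccc(Br)cc3)CC(c3ccc(O)c(OC)c3)N2C)ccc1O`, gives 112000 nM in this assay, and compound 2, `COc1cc(C2CC(=NOC(=O)c3cccc(O)c3)CC(c3ccc(O)c(OC)c3)N2C)ccc1O`, gives 25300 nM in the same assay.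

The step to compound 4, `COc1cc(C2CC(=NOC(=O)c3ccc(F)cc3)CC(c3ccc(O)c(OC)c3)N2C)ccc1O`, is fluoro in place of chloro on an aromatic carbon. Going by the values given here, only one measured step changes the same position: a 1.1-fold lower number from compound 1 to compound 3 (0.03 log units; within the scatter), which is within the scatter. The other steps, a 4.8-fold lower number from compound 1 to compound 2 (0.68 log units; beyond the scatter) and a 4.4-fold higher number from compound 2 to compound 3 (0.65 log units; beyond the scatter), replace the whole ring group rather than one substituent on it, so they say less about a single-atom exchange at that place.

Because a 1.1-fold lower number from compound 1 to compound 3 (0.03 log units; within the scatter) did not move the number beyond the scatter, the expectation for compound 4 is a step of similar size, a 1.1-fold lower number from compound 1 to compound 4 (0.02 log units; within the scatter), with no clear direction. Compound 4 is therefore estimated to give about 115000 nM in this assay, with a range from 55000 nM to 240000 nM.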

Compound 4, half-maximal inhibitory concentration: 140000 nM
For compound 4 the middle estimate is 1.2-fold (0.09 log units) below the measured one; the range from low to high includes it.
By their numbers in this assay, from the lowest: compound 2; then compounds 3, 1 and 4 (each within the scatter of the next).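

Replacing chloro with fluoro gives a 1.2-fold higher number from compound 1 to compound 4 (0.06 log units; within the scatter) in this assay, and replacing bromo with fluoro gives a 1.3-fold higher number from compound 3 to compound 4 (0.10 log units; within the scatter) as well, so the 4-chlorophenyl, 4-bromophenyl and 4-fluorophenyl compounds now form a set of three whose numbers all lie within the scatter of one another. The identity of the halogen at this place therefore makes no readable difference across the three halogens shown, and the exchange of one single atom for another leaves the number where it was. The only large gap remains the one to the 3-hydroxyphenyl group, seen again in a 5.5-fold higher number from compound 2 to compound 4 (0.74 log units; beyond the scatter) as a step beyond the scatter, and nothing among the data shown offers a reason for that gap or for the flatness among the halogens.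

The compounds shown do not separate the effect of the hydroxy group in compound 2 from the effect of where it sits on the ring. On these data alone, it also remains open whether an amine or a carboxylic acid on that ring would give a number close to compound 2 or close to the three halogen compounds.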